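A few compounds are considered here, and "the series" means these few. Any claim that something is new, unique, unknown or untested is made for them only; others in the source may bear on it.

In a functional assay on DU-145 cells (Homo sapiens) for inhibition, read by trypan blue exclusion, with a stated time of 96 h (on this read-out higher numbers stand for weaker inhibition of growth and lower numbers for stronger inhibition of growth), compound 2 (`COc1ccccc1/C=C(\C(=O)c1ccc(Cl)cc1)S(=O)(=O)c1ccc(Br)cc1`) gives 10000 nM and compound 3 (`COc1ccc(/C=C(\C(=O)c2ccc(Cl)cc2)S(=O)(=O)c2ccc(Br)cc2)cc1O`) gives 10000 nM as the two measured numbers, so compound 3 stands level with compound 2. Compound 1 (`O=C(/C(=C\c1c(O)cc(O)cc1O)SCc1ccc(Cl)cc1)c1ccc(Cl)cc1`) gives > 100000 nM in the same test, and this is a limit of the assay, not a number.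

The next compound, compound 4 (`O=C(/C(=C\c1c(O)cc(O)cc1O)S(=O)(=O)c1ccc(Br)cc1)c1ccc(Cl)cc1`), changes one group of compound 3: 2,4,6-trihydroxyphenyl in place of 3-hydroxy-4-methoxyphenyl on a double-bonded chain carbon bound to a double-bonded chain carbon. Within the data shown here, only one measured step changes a group at this same place, and it shows no change at the digits printed from compound 2 to compound 3 (within the scatter) in this single case. That step gives no reason to expect a large move here, so no step beyond the scatter is expected in this assay, and the estimate is a 1.2-fold higher number from compound 3 to compound 4 (0.08 log units; within the scatter) for this swap.

Compound 1 also carries 2,4,6-trihydroxyphenyl, though it differs elsewhere too, so the estimated range stays wider on the weaker side. The estimate for compound 4 is 12000 nM as the expected value, with an expected range from 3000 nM to 60000 nM for this measurement.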

Compound 4, concentration for 50% growth inhibition: > 100000 nM
Compound 4: only a limit was reported; the forecaster's own chance of this, stated with the estimate: 15%; at least 8.3-fold (0.92 log units) between middle value and limit.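

Among these compounds, the place on a double-bonded chain carbon bound to a double-bonded chain carbon is not indifferent to what sits there, which the one earlier step, no change at the digits printed from compound 2 to compound 3 (within the scatter), could not show. In this assay, 2,4,6-trihydroxyphenyl in place of 3-hydroxy-4-methoxyphenyl gives an at least 10-fold higher number from compound 3 to compound 4 (1.00 log units; beyond the scatter), and in place of 2-methoxyphenyl it gives an at least 10-fold higher number from compound 2 to compound 4 (1.00 log units; beyond the scatter) as well, so two different starting groups point the same way. Each step is only a minimum, since compound 4 is reported as a limit and not a number: the limit of > 100000 nM in this assay, at which 2 of the 4 values shown sit.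

The step between compound 1 and compound 4 cannot be read, as both values are limits. On these data alone, it also stays open whether the weaker growth inhibition belongs to 2,4,6-trihydroxyphenyl as a whole or to one of its hydroxyl groups, and how an amine or a carboxylic acid on the phenyl ring at this place would behave.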